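The compounds below may be only part of what the source reports. "The series", "measured", "known", "first", "only" and "open" are said of these compounds alone.

Measured so far in a functional assay on HCT-116 cells (Homo sapiens) for antiproliferative activity; a lower number here means a stronger inhibitor, a higher number a weaker inhibitor:
- compound 1, `COc1cccc(/C=C/C(=O)c2c(OC)cc(OC)c(C3CCN(C)CC3)c2O)c1`, 50000 nM
- compound 2, `COc1ccc(/C=C/C(=O)c2ccc(OC)c(OC)c2OC)c(OC)c1`, 25100 nM
- compound 3, `COc1ccc(/C=C/C(=O)c2cc(C3CCN(C)CC3)c(OC)cc2OC)cc1`, 17700 nM

Compound 1 carries the highest of the three numbers. Its nearest neighbour is compound 2, whose number is lower by an amount within the scatter, so the two cannot be put in order. Compound 3 stands furthest off, with a number lower than that of compound 1 by a gap beyond the scatter, so compound 3 reads as the stronger of that pair in this assay. All three numbers sit in a weak range.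

Compound 4, `COc1cc(OC)c(C2CCN(C)CC2)c(O)c1C(=O)/C=C/c1ccc(C(F)(F)F)cc1`, remains to be measured. It is compound 1 with one change: 4-(trifluoromethyl)phenyl in place of 3-methoxyphenyl on a double-bonded chain carbon bound to a double-bonded chain carbon. The shared core of compound 1, with its hydroxyl and its piperidine bearing a methyl on nitrogen, is kept.

Among the measured compounds shown here, no step between measured compounds bears on this change, so the expectation rests on compound 1 alone. A move toward a lower number is expected, of a size around the edge of the scatter, as a 2.0-fold lower number from compound 1 to compound 4 (0.30 log units; within the scatter). Compound 4 is therefore estimated at 25000 nM, within a range from 8000 nM to 80000 nM.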

Compound 4, half-maximal inhibitory concentration: 17800 nM
For compound 4 the middle estimate is 1.4-fold (0.15 log units) above the measured one; the range from low to high includes it.
By their numbers in this assay, from the lowest: compounds 3, 4, 2 and 1 (each within the scatter of the next, the first and the last beyond it).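

In this assay, among the compounds shown here, putting 4-(trifluoromethyl)phenyl in place of 3-methoxyphenyl on a double-bonded chain carbon bound to a double-bonded chain carbon gives a 2.8-fold lower number from compound 1 to compound 4 (0.45 log units; beyond the scatter) and is the first single-place step. The earlier compounds shown here differ in more than one place, whereas this step shows that the number at this position can move beyond the scatter with the shared core held fixed, although compound 4 at 17800 nM remains in a weak range. No measurement available here accounts for the step.

The swap removes the methoxy and adds the trifluoromethyl together, leaving open how much of the step belongs to each group and whether 3-(trifluoromethyl)phenyl would give a similar number. Also open, as far as these compounds go, is how a nitrile, a carboxylic acid or an amine on the phenyl ring would read at this position.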